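Methoxy to Methyl, Seen Once, Expected Again

A few compounds are considered here, and "the series" means these few. Any claim that something is new, unique, unknown or untested is made for them only; others in the source may bear on it.

Compound 2 `CCOC(=O)c1nn(-c2ccc(OC)cc2)/c(=N/c2nc(-c3c(C)n(C)n(-c4ccccc4)c3=O)cs2)s1` gives 15900 nM in a functional assay on MCF7 cells (Homo sapiens) for cytotoxicity, read by sulforhodamine B assay, with a stated time of 72 h; a lower number here means a stronger inhibitor, a higher number a weaker inhibitor.
Compound 3 `COc1ccc(/C=C2\S/C(=N\c3nc(-c4c(C)n(C)n(-c5ccccc5)c4=O)cs3)N(c3ccccc3)C2=O)cc1` gives 26100 nM in this assay.
Compound 1 `CCOC(=O)c1nn(-c2ccc(C)cc2)/c(=N/c2nc(-c3c(C)n(C)n(-c4ccccc4)c3=O)cs2)s1` reaches only a limit of this assay, > 100000 nM.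

Compound 2 and compound 1 differ by one change, (methyl in place of methoxy on an aromatic carbon), and that change gave an at least 6.2-fold higher number from compound 2 to compound 1 (0.79 log units; beyond the scatter); the size is bounded because compound 1 sits at the limit of > 100000 nM in this assay, at which 1 of the 3 values shown sits. Compound 4 `Cc1ccc(/C=C2\S/C(=N\c3nc(-c4c(C)n(C)n(-c5ccccc5)c4=O)cs3)N(c3ccccc3)C2=O)cc1` differs from compound 3 by the same change, (methyl in place of methoxy on an aromatic carbon), and both "place" descriptions agree word for word, so it is the same change in a different setting. The difference between the two cores is not broken down here. Compound 3 and compound 2 lie within the scatter of each other. Starting from compound 3, the step to compound 4 is expected to be a 4.6-fold higher number from compound 3 to compound 4 (0.66 log units; beyond the scatter), resting on the measured change from compound 2 to compound 1. Compound 4 is therefore estimated at 120000 nM, between 40000 nM and 400000 nM, quite possibly only a limit.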

Compound 4, half-maximal inhibitory concentration: > 100000 nM
Compound 4: only a limit was reported (the forecaster's own chance of this, stated with the estimate: 55%); the middle value does not contradict the limit.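

In this assay, replacing 4-methoxyphenyl with 4-methylphenyl again weakens the compound, with an at least 3.8-fold higher number from compound 3 to compound 4 (0.58 log units; beyond the scatter). The direction of the change therefore carries over between these two cores, and on both the step lies beyond the scatter: the same change on two cores in this assay, an at least 6.2-fold higher number (0.79 log units; beyond the scatter) from compound 2 to compound 1 and an at least 3.8-fold higher number (0.58 log units; beyond the scatter) from compound 3 to compound 4; the limit leaves it open whether they differ

What this does not show is the true size of either step, since compound 1 and compound 4 give only a limit and not a number: the limit of > 100000 nM in this assay, at which 2 of the 4 values shown sit.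

The compounds shown leave open how an amine, a hydroxyl or a chlorine atom would behave in the same place on the ring. They also leave open whether the same change would act in the same direction on a third core.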